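Piperazine in place of the methylated cyclohexylamine

This account rests on a few compounds, and the source may have more. Where it says the series, first, only, none or still open, it means among the compounds named here.

In an assay on isolated protein for antagonist activity at Bile acid receptor (Homo sapiens), read by HTRF, with a stated time of 30 min (a lower number here means a stronger inhibitor, a higher number a weaker inhibitor), compound 1 `CC(C)(C)c1cc(NC(=O)c2c(Cl)cc(NC3CCCCC3)cc2Cl)ccc1O` gives 2500 nM. Compound 2 `CN(c1cc(Cl)c(C(=O)Nc2ccc(O)c(C(C)(C)C)c2)c(Cl)c1)C1CCCCC1` is reported only as a limit in this assay, > 100000 nM, and so the pair shows an at least 40-fold higher number from compound 1 to compound 2 (1.60 log units; beyond the scatter), a change that is a methyl in place of hydrogen on a nitrogen on an aromatic ring. Compound 2 therefore stands at the weak end of the two numbers shown, and the limit of > 100000 nM in this assay, at which 1 of the 2 values shown sits, means that the gap to compound 1 may in truth be even wider than the figure quoted. Compound 3 `CC(C)(C)c1cc(NC(=O)c2c(Cl)cc(N3CCNCC3)cc2Cl)ccc1O` is related to compound 2 by piperazin-1-yl in place of cyclohexyl(methyl)amino on an aromatic carbon. Within the data shown here, the only measured step that bears on this change is the one from compound 1 to compound 2, which was large and ran toward a weaker inhibitor when the nitrogen on the aromatic ring carried a methyl; compound 3 removes that methyl along with the cyclohexyl and brings in a ring bearing a free hydrogen-bond donor, so in this assay a step back toward lower numbers is expected, and the author estimates an at least 10-fold lower number from compound 2 to compound 3 (1.00 log units; beyond the scatter). For compound 3 the estimated value is 10000 nM, with a range from 1500 nM to 60000 nM.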

Compound 3, half-maximal inhibitory concentration: > 100000 nM
Compound 3: only a limit was reported; the forecaster's own chance of this, stated with the estimate: 25%; middle value at least 10-fold (1.00 log units) away from the limit.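

In this assay, compound 3 gives > 100000 nM, which is a limit and not a number. Piperazin-1-yl in place of cyclohexylamino on this aromatic carbon brings an at least 40-fold higher number from compound 1 to compound 3 (1.60 log units; beyond the scatter), so the hydrogen-bond donor that enters with piperazin-1-yl does not return a measurable value, and compound 1 remains the only one of the three with a readable number. The step between compound 2 and compound 3 cannot be read, and any difference between these two stays hidden: the limit of > 100000 nM in this assay, at which 2 of the 3 values shown sit.

The compounds shown leave open whether compound 1 owes its readable value to the hydrogen on the nitrogen attached to the aromatic ring, to the ring of carbon only, or to both. A piperidin-1-yl group, which has a ring but no such hydrogen, or a cyclopentylamino or butylamino group, which keeps that hydrogen and alters what is attached to the nitrogen, would begin to separate these possibilities at this aromatic carbon.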